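Working notes: from compound 3 to compound 4

The source may hold more compounds than are shown below. What is called first, only, known or untested is meant among the compounds shown, and "the series" means these compounds.

Measured in a functional assay on A-375 cells (Homo sapiens) for antiproliferative activity, read by MTT assay, with a stated time of 48 h; on this read-out higher numbers stand for weaker inhibition of growth and lower numbers for stronger inhibition of growth:
compound 1 `Fc1ccc(C2=NN(C(=S)Nc3ccccc3)C(c3ccc4c(c3)OCCO4)C2)cc1`: 15700 nM
compound 2 `S=C(Nc1ccccc1)N1N=C(c2ccc(Br)cc2)CC1c1ccc2c(c1)OCCO2`: 470 nM
compound 3 `Cc1ccc(C2=NN(C(=S)Nc3ccccc3)C(c3ccc4c(c3)OCCO4)C2)cc1`: 6320 nM

Compound 3 holds the second highest number of the three, nearer to compound 1 than to compound 2, as shown by a 2.5-fold lower number from compound 1 to compound 3 (0.40 log units; beyond the scatter) and a 13-fold higher number from compound 2 to compound 3 (1.13 log units; beyond the scatter). Compound 4 `CSc1ccc(C2=NN(C(=S)Nc3ccccc3)C(c3ccc4c(c3)OCCO4)C2)cc1` is not yet measured. It differs from compound 3 by methylsulfanyl in place of methyl on an aromatic carbon. Every change made so far on that aromatic carbon moved the number beyond the scatter, one modestly and one by a large step, and a 33-fold lower number from compound 1 to compound 2 (1.52 log units; beyond the scatter) gives a second large step there. For the measured compounds named here, no measured step involves methylsulfanyl, so the direction is open. A step beyond the scatter in this assay is expected, with wide uncertainty. Compound 4 is estimated at 2500 nM with a range from 400 nM to 12000 nM. This estimate corresponds to an expected 2.5-fold lower number from compound 3 to compound 4 (0.40 log units; beyond the scatter).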

Compound 4, concentration for 50% growth inhibition: 159000 nM
Compound 4: the middle estimate sits 64-fold (1.80 log units) below what was measured; the whole stated range lies below it.
By their numbers in this assay, from the lowest: compound 2; then compound 3; then compound 1; then compound 4.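

In this assay, for the compounds shown here, methylsulfanyl is the first group on this aromatic carbon to give a higher number than fluoro, with a 10-fold higher number from compound 1 to compound 4 (1.01 log units; beyond the scatter) in the series. Against the methyl group the change gives a 25-fold higher number from compound 3 to compound 4 (1.40 log units; beyond the scatter), and against bromo it gives a 340-fold higher number from compound 2 to compound 4 (2.53 log units; beyond the scatter), so the span at this single position is now much wider than any earlier step showed. No measurement on these compounds accounts for this result.

The compounds shown leave open where chloro, methoxy or a longer alkylsulfanyl chain would fall on this aromatic carbon. They also leave open whether methylsulfonyl would track methylsulfanyl.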